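Shortening the chain of compound 2 towards compound 4

The source may report more compounds than this note shows. Statements on the series, on what has been measured and on what is new or still open speak of the compounds shown alone.

Compound 1 `CCCCCCNNC(=O)c1cccc(NCc2ccccc2)c1` gives > 20000 nM in an assay on isolated protein for inhibition of histone deacetylase 4 (Homo sapiens) (a lower number here means a stronger inhibitor, a higher number a weaker inhibitor), a limit of the assay.
Compound 2 `CCCCCCNNC(=O)c1cnc(N2CCN(Cc3c[nH]c4ccccc34)CC2)nc1` gives > 20000 nM in this assay, a limit of the assay.
Compound 3 `CCCNNC(=O)c1ccc(-c2ccc(CNC(C)=O)cc2)cc1` gives 990 nM in this assay.

Compound 2 stands on a limit rather than a measured number, namely (the limit of > 20000 nM in this assay, at which 2 of the 3 values shown sit), so the only thing known of it is that it is a weak inhibitor. Compound 3, with a different core, is the only one of the three that gives a number, and that number lies well inside the measurable range of this assay.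

Compound 4 `CCCNNC(=O)c1cnc(N2CCN(Cc3c[nH]c4ccccc34)CC2)nc1` differs from compound 2 in one place: hydrogen in place of propyl on a saturated chain carbon, three bonds along the chain from an amine nitrogen. Among the measured compounds shown here, whether taking this much of the chain away will pull compound 2 out of the limit is open, since no measured pair shows this change on the shared core. The expectation is a modest gain at best, with a real chance that compound 4 again lands on the limit.

For compound 4 the estimate is 9000 nM, with a range from 1500 nM to 20000 nM. The step this expectation implies is an at least 2.2-fold lower number from compound 2 to compound 4 (0.34 log units; beyond the scatter).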

Compound 4, half-maximal inhibitory concentration: > 20000 nM
Compound 4: a limit, no number; the forecaster's own chance of this, stated with the estimate: 45%; middle value at least 2.2-fold (0.34 log units) away from the limit.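

Compound 4, like compound 2, sits on a limit of the assay rather than a number, so no step between these two compounds can be read: the limit of > 20000 nM in this assay, at which 3 of the 4 values shown sit.

From the compounds shown here alone, how much hydrogen in place of propyl changes inhibition on this shared core remains open.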